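This account rests on a few compounds, and the source may have more. Where it says the series, first, only, none or still open, it means among the compounds named here.

In a functional assay on K562 cells (Homo sapiens) for antiproliferative activity, read by MTT assay, with a stated time of 48 h (on this read-out higher numbers stand for weaker inhibition and lower numbers for stronger inhibition), compound 1 `Cn1cc(C2=C(c3nn(CCCn4cccc4)c4ncccc34)C(=O)NC2=O)c2ccccc21` gives 21600 nM, the higher of the two numbers in the series, and compound 2 `Cn1cc(C2=C(c3nn(CCCN4CCCCC4)c4ncccc34)C(=O)N(c3cccc4ccccc34)C2=O)c2ccccc21` gives 3180 nM, a gap beyond the scatter. Compound 3 `Cn1cc(C2=C(c3nn(CCCN4CCCCC4)c4ncccc34)C(=O)N(c3ccccn3)C2=O)c2ccccc21` gives > 100000 nM, which is a limit of the assay and not a number.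

Compound 4 `Cn1cc(C2=C(c3nn(CCCn4ccnc4)c4ncccc34)C(=O)NC2=O)c2ccccc21` alters only the chain end of compound 1: 1H-imidazol-1-yl in place of 1H-pyrrol-1-yl on a saturated chain carbon, three bonds along the chain from an aromatic nitrogen. Going by the values given here, no measured step covers this swap. The nearest is an at least 31-fold higher number from compound 2 to compound 3 (1.49 log units; beyond the scatter), a large step with pyridin-2-yl entering in place of naphthalen-1-yl. It lies at another place, on an amide-type nitrogen in a ring, and on compounds with a different chain, so it bears only weakly. No step beyond the scatter is therefore expected in this assay, with any drift more likely towards a higher number. The expected step is a 1.1-fold higher number from compound 1 to compound 4 (0.05 log units; within the scatter). For compound 4 the estimate is 24000 nM, with an expected range of 7000 nM to 80000 nM.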

Compound 4, half-maximal inhibitory concentration: 13800 nM
For compound 4 the middle estimate is 1.7-fold (0.24 log units) above the measured one; the measured number falls inside the stated range.
By their numbers in this assay, from the lowest: compound 2; then compounds 4 and 1 (each within the scatter of the next). At a limit, above all of these: compound 3.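

In this assay, the swap of 1H-pyrrol-1-yl for 1H-imidazol-1-yl on a saturated chain carbon, three bonds along the chain from an aromatic nitrogen, gives a step within the scatter (a 1.6-fold lower number from compound 1 to compound 4 (0.19 log units; within the scatter)). Going by these compounds alone, this is the only measured step at the chain end, and it shows that exchanging one ring carbon for a nitrogen, with one more hydrogen-bond acceptor by count, leaves the read-out unresolved here, unlike the large step on the amide-type nitrogen. Nothing shown bears on a cause for this result.

On these data alone, it remains open whether a morpholin-4-yl or dimethylamino group at the end of the propyl chain, or a longer chain carrying either ring, would move the number beyond the scatter. The compounds shown also leave open whether this swap would give a similar step with naphthalen-1-yl in place of the amide hydrogen.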